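Aryl variation on the shared core: cytotoxicity series notes

A few compounds are considered here, and "the series" means these few. Any claim that something is new, unique, unknown or untested is made for them only; others in the source may bear on it.

compound 1 `CCS(=O)(=O)Nc1cc(-c2ccc3ncnc(Nc4ccc(F)cc4F)c3c2)cnc1OC`: 2050 nM
compound 2 `CCS(=O)(=O)Nc1cc(-c2ccc3ncnc(Nc4ccc(OC)c(Cl)c4)c3c2)cnc1OC`: 3620 nM
compound 3 `CCS(=O)(=O)Nc1cc(-c2ccc3ncnc(Nc4ccc(OCc5ccc(F)cc5)c(Cl)c4)c3c2)cnc1OC`: 2360 nM

All three were read in a functional assay on SNU-638 cells (Homo sapiens) for cytotoxicity, read by sulforhodamine B assay, with a stated time of 72 h; on this read-out lower numbers stand for stronger inhibition and higher numbers for weaker inhibition. Compound 2 gives the highest of the three numbers in this assay, yet compound 3 as its nearest neighbour and compound 1 as its furthest both lie within the scatter of it, so no ranking is drawn. Compound 4 `CCS(=O)(=O)Nc1cc(-c2ccc3ncnc(Nc4ccc(OC)nc4)c3c2)cnc1OC` carries the change (6-methoxypyridin-3-yl in place of 3-chloro-4-methoxyphenyl on a nitrogen on an aromatic ring). Among the compounds with values here, two steps bear on it: a 1.8-fold higher number from compound 1 to compound 2 (0.25 log units; within the scatter), an aryl swap on that same nitrogen, and a 1.5-fold lower number from compound 2 to compound 3 (0.19 log units; within the scatter). Neither moved beyond the scatter, so the expected step of a 1.2-fold lower number from compound 2 to compound 4 (0.08 log units; within the scatter) is likewise none beyond it. Compound 4 is accordingly estimated at 3000 nM, with a range of 1200 nM to 7500 nM.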

Compound 4, half-maximal inhibitory concentration: 4280 nM
Estimate against measurement, compound 4: 1.4-fold (0.15 log units) below, within the range that was stated.
By their numbers in this assay, from the lowest: compounds 1, 3, 2 and 4 (each within the scatter of the next, the first and the last beyond it).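

On the nitrogen on an aromatic ring, 6-methoxypyridin-3-yl in place of 3-chloro-4-methoxyphenyl gives a 1.2-fold higher number from compound 2 to compound 4 (0.07 log units; within the scatter), so putting a hetero atom into this ring and losing the chlorine leaves no resolved change. Within the data shown here, the same group in place of 2,4-difluorophenyl gives a 2.1-fold higher number from compound 1 to compound 4 (0.32 log units; beyond the scatter), the first step at this position to pass the scatter, though only modestly. Nothing at hand bears on the origin of either step.

Open, going by these compounds, is whether an aryl group carrying a dimethylamino or carboxylic acid substituent on this nitrogen would move the number further.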